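Swapping methoxy for acetyl on the aryl ring of a CRF receptor ligand

This account rests on a few compounds, and the source may have more. Where it says the series, first, only, none or still open, it means among the compounds named here.

Of the compounds shown here, two sharing one core have been measured in an assay on frontal cortex for displacement of a labelled ligand from corticotropin-releasing factor receptor 1 (Rattus norvegicus); a lower number here means a stronger inhibitor, a higher number a weaker inhibitor. Compound 1, `CCCCN(CC)c1nc(C)nc2c1NC(=O)CN2c1ccc(OC)cc1C`, carries a carbonyl in its second ring and gives 95 nM. Compound 2, `CCCCN(CC)c1nc(C)nc2c1NCCN2c1ccc(OC)cc1C`, lacks that carbonyl and gives 11.7 nM. Of the two numbers, compound 2 stands lowest, and its gap to compound 1 lies beyond the usual scatter, so compound 2 is the stronger inhibitor of this pair.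

Compound 3, `CCCCN(CC)c1nc(C)nc2c1NCCN2c1ccc(C(C)=O)cc1C`, keeps the core of compound 2 and changes only the aryl ring: acetyl in place of methoxy on an aromatic carbon. Among the compounds with values here, no measured pair shows this exchange, so its effect is unknown. The expectation is a small step toward a weaker inhibitor, possibly within the scatter, with a 2.1-fold higher number from compound 2 to compound 3 (0.33 log units; beyond the scatter) as the estimated size. Compound 3 is therefore expected to give about 25 nM in this assay, between 8 nM and 80 nM.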

Compound 3, half-maximal inhibitory concentration: 172 nM
For compound 3 the middle estimate is 6.9-fold (0.84 log units) below the measured one, and the stated range ends below it.
By their numbers in this assay, from the lowest: compound 2; then compounds 1 and 3 (each within the scatter of the next).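

Within the data shown here, until now, no measured pair spoke to this position on the aryl ring, para to a large group and meta to a methyl group. In this assay, acetyl in place of methoxy gives a 15-fold higher number from compound 2 to compound 3 (1.17 log units; beyond the scatter) and counts as a large step, so this position is sensitive to the group it carries, even though both groups have the same counts of hydrogen-bond donors and acceptors. Nothing measured here explains the size of this step.

Going by these compounds, with only methoxy and acetyl at this position, it remains open whether a chlorine atom, a dimethylamino group or a longer ethoxy chain would give a number closer to that of compound 2 or compound 3. Also open, on these data alone, is whether the same exchange would have a similar effect on the core of compound 1, which carries the carbonyl.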